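Swapping trifluoromethyl for cyano on a sulfonyl aryl group

The source may hold more compounds than are shown below. What is called first, only, known or untested is meant among the compounds shown, and "the series" means these compounds.

compound 1 `CN1C/C(=C\c2ccncc2)C(=O)/C(=C/c2ccccc2C(F)(F)F)C1`: 4100 nM
compound 2 `N#Cc1ccc(S(=O)(=O)N2C/C(=C\c3ccncc3)C(=O)/C(=C/c3ccccc3F)C2)cc1`: 16200 nM
compound 3 `O=C1/C(=C/c2ccncc2)CN(S(=O)(=O)c2ccc(C(F)(F)F)cc2)C/C1=C\c1ccccc1C(F)(F)F`: 3840 nM

In a functional assay on SMMC-7721 cells (Homo sapiens) for cytotoxicity, read by MTT assay, with a stated time of 24 h (on this read-out higher numbers stand for weaker inhibition and lower numbers for stronger inhibition), compound 3 gives 3840 nM and lies within the scatter of compound 1, while compound 2 stands beyond the scatter from it, with a higher number. Compound 4 `N#Cc1ccc(S(=O)(=O)N2C/C(=C\c3ccncc3)C(=O)/C(=C/c3ccccc3C(F)(F)F)C2)cc1` differs from compound 3 in one place: cyano in place of trifluoromethyl on an aromatic carbon, para to a large group (cyano in place of trifluoromethyl on an aromatic carbon). Among the compounds with values here, no measured pair shows this change alone, so the expectation is loose. Compound 2 also carries 4-cyanophenyl and gives 16200 nM, which hints at weaker inhibition, although it differs in another place as well. The expected change is small and toward weaker inhibition, probably within the scatter: a 1.6-fold higher number from compound 3 to compound 4 (0.19 log units; within the scatter). The estimated value for compound 4 is 6000 nM, with an expected range from 2500 nM to 15000 nM.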

Compound 4, half-maximal inhibitory concentration: 9610 nM
For compound 4 the middle estimate is 1.6-fold (0.20 log units) below the measured one; measured number inside the range.
By their numbers in this assay, from the lowest: compounds 3 and 1 (each within the scatter of the next); then compounds 4 and 2 (each within the scatter of the next).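

In this assay, within the data shown here, cyano in place of trifluoromethyl on an aromatic carbon, para to a large group, gives a 2.5-fold higher number from compound 3 to compound 4 (0.40 log units; beyond the scatter), the first reading of this change alone. With the same 4-cyanophenyl group kept, (4-cyanophenyl)sulfonyl in place of methyl on the ring nitrogen gives a 2.3-fold higher number from compound 1 to compound 4 (0.37 log units; beyond the scatter). Trifluoromethyl in place of fluoro on an aromatic carbon gives a 1.7-fold lower number from compound 2 to compound 4 (0.23 log units; within the scatter), so that change shows no clear effect.

Nothing measured here accounts for these steps. As far as these compounds go, how an amine or a carboxylic acid would behave at this position remains open.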